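Second Substituent on a Glycine Transporter Inhibitor Ring

The source may report more compounds than this note shows. Statements on the series, on what has been measured and on what is new or still open speak of the compounds shown alone.

Measured so far:
compound 1 `COc1cc(C(F)(F)F)ccc1C(=O)NC1(c2ccccc2)CCCN(C)C1`: 4800 nM
compound 2 `CSc1cc(C(F)(F)F)ccc1C(=O)NC1(c2ccccc2)CCCN(C)C1`: 67 nM

Both compounds share one core and differ only in a single group on the aromatic ring. In an assay on cells for inhibition of sodium- and chloride-dependent glycine transporter 1 (Homo sapiens) (a higher number here means that more compound is needed for the effect, a lower number that less compound is needed), compound 1 gives 4800 nM, while compound 2 gives 67 nM, a change of a 72-fold lower number from compound 1 to compound 2 (1.86 log units; beyond the scatter). Among the compounds with values here, compound 2 therefore holds the lower of the two numbers, and compound 1 is its only point of comparison.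

Compound 3 `COc1cc(C(F)(F)F)cc(SC)c1C(=O)NC1(c2ccccc2)CCCN(C)C1` keeps the methylsulfanyl group of compound 2 and adds a further group: methoxy in place of hydrogen on an aromatic carbon. Within the data shown here, no measured step covers this kind of addition; the one step known, from compound 1 to compound 2, concerns an exchange of one group for another, not the presence of both at once. Compound 3 keeps the group that accompanies the low number of compound 2 and gains the group that compound 1 carried alone, so a moderate rise in this assay is expected, with wide uncertainty. Compound 3 is estimated at 180 nM, within 40 nM to 900 nM, an expected step of a 2.7-fold higher number from compound 2 to compound 3 (0.43 log units; beyond the scatter).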

Compound 3, half-maximal effective concentration: 24 nM
For compound 3 the middle estimate is 7.5-fold (0.88 log units) above the measured one; the measured number lies below the stated range.
By their numbers in this assay, from the lowest: compound 3; then compound 2; then compound 1.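

In this assay, methoxy in place of hydrogen on the aromatic carbon ortho to a large group and meta to a methylsulfanyl group gives a 2.8-fold lower number from compound 2 to compound 3 (0.45 log units; beyond the scatter), so a methoxy group is accepted at this position, at least when methylsulfanyl is present. Read from the other side, methylsulfanyl in place of hydrogen gives a 200-fold lower number from compound 1 to compound 3 (2.30 log units; beyond the scatter) and shows that a methoxy group does not by itself hold a compound at a high number: compound 3 carries methoxy and still has the lowest number of the three, which the exchange between compound 1 and compound 2 alone could not reveal. The data show that the two groups together give a lower number than either alone, but nothing here explains why.

The compounds shown leave open whether the drop depends on the methoxy oxygen or on the added group as a whole, which a hydroxyl group or a plain methyl group at this position could help to separate. They also leave open how far the position reaches, for example with a longer chain such as ethoxy or with an amine.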